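Swapping methoxy for hydroxy: what to expect

The source may hold more compounds than are shown below. What is called first, only, known or untested is meant among the compounds shown, and "the series" means these compounds.

Compound 1 `Cc1ccc2nc(NC(=O)/C=C/c3ccc(O)cc3)sc2c1` gives 271 umol/kg as its value
Compound 2 `O=C(/C=C/c1ccc(O)cc1)Nc1nc2ccccc2s1` gives 517 umol/kg as its value
Compound 3 `COc1ccc(/C=C/C(=O)Nc2nc3ccc(Cl)cc3s2)cc1` gives 259 umol/kg as its value

These values come from a functional assay on the whole organism (Hindlimb, strain albino) with Mus musculus as the target, in the maximal electroshock model, with a stated time of 0.5 h (on this read-out higher numbers stand for an effect only at larger amounts of compound and lower numbers for an effect already at smaller amounts), and the value of compound 3 lies within the usual scatter of both compound 1 and compound 2. Compound 4 `O=C(/C=C/c1ccc(O)cc1)Nc1nc2ccc(Cl)cc2s1` differs from compound 3 by one change: hydrogen in place of methyl on an oxygen on an aromatic ring, in short methoxy to hydroxy. Going by the values given here, no measured pair shows this change. Among the compounds with values here, the only measured step, a 1.9-fold higher number from compound 1 to compound 2 (0.28 log units; within the scatter), concerns a different place and offers indirect guidance at best. Compound 1 and compound 2 already carry hydroxy, and neither value leaves the scatter around compound 3. The expected step is therefore a 1.0-fold higher number from compound 3 to compound 4 (0.02 log units; within the scatter), nothing beyond the scatter. For compound 4 the estimated value is 270 umol/kg, with an expected range from 120 umol/kg to 600 umol/kg in this measurement.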

Compound 4, dose for half-maximal effect: 322 umol/kg
Estimate against measurement, compound 4: 1.2-fold (0.08 log units) below; measured number inside the range.
By their numbers in this assay, from the lowest: compounds 3, 1, 4 and 2 (each within the scatter of the next).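

In this assay the methoxy to hydroxy change now has a measured pair (a 1.2-fold higher number from compound 3 to compound 4 (0.09 log units; within the scatter)), and removing the methyl from that oxygen leaves the value within the scatter. On the aromatic carbon, chloro also stays within the scatter of hydrogen (a 1.6-fold lower number from compound 2 to compound 4 (0.21 log units; within the scatter)) and of methyl (a 1.2-fold higher number from compound 1 to compound 4 (0.07 log units; within the scatter)). Nothing measured here offers a reason for these small steps. As far as these compounds go, it remains open whether an amine or a carboxylic acid on the aromatic ring in place of the hydroxy would give a step beyond the scatter. The same question stands for a longer chain on that oxygen.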